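A Nitrile Replaces Chlorine on the Benzyl Arm

The compounds below may be only part of what the source reports. "The series", "measured", "known", "first", "only" and "open" are said of these compounds alone.

Compound 1 `O=c1ccoc2cc(OCc3cn(Cc4ccc(Cl)cc4)nn3)ccc12` was tested in a functional assay on A549 cells (Homo sapiens) for cytotoxicity, read by MTT assay, with a stated time of 48 h; a lower number here means a stronger inhibitor, a higher number a weaker inhibitor. In this assay compound 1 reaches only the limit of the assay, > 100000 nM. Compound 2 `O=c1ccoc2cc(OCc3cn(Cc4ccc(F)cc4)nn3)ccc12` is likewise reported at a limit, > 100000 nM. The step that the two limits leave unreadable from compound 1 to compound 2 therefore cannot be sized, and the limit of > 100000 nM in this assay, at which 2 of the 2 values shown sit, covers both values shown. Compound 3 `N#Cc1cccc(Cn2cc(COc3ccc4c(=O)ccoc4c3)nn2)c1` differs from compound 1 in one place: 3-cyanophenyl in place of 4-chlorophenyl on a saturated chain carbon bound to an aromatic nitrogen. Among the compounds with values here, no measured step bears on this exchange, as the one comparison available, fluoro for chloro, is itself unreadable. Compound 1 is reported only at the limit > 100000 nM in this assay, and compound 3 is expected to behave alike. Compound 3 is estimated at 150000 nM, within 50000 nM to 500000 nM. The step that the limit leaves unreadable from compound 1 to compound 3 is expected to stay within scatter, with the result most likely reported once more as a limit.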

Compound 3, half-maximal inhibitory concentration: 14300 nM
The estimate for compound 3 lay 10-fold (1.02 log units) above the measured number; measured number outside the range, below it.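

The place on a saturated chain carbon bound to an aromatic nitrogen can move the result in this assay, which the fluoro for chloro exchange could not show. With 3-cyanophenyl at this place, the result is an at least 6.9-fold lower number from compound 1 to compound 3 (0.84 log units; beyond the scatter), and the same holds against the fluoro analogue, with an at least 6.9-fold lower number from compound 2 to compound 3 (0.84 log units; beyond the scatter). Compound 1 and compound 2 remain at a limit of the assay rather than a number, so these steps give only a minimum size: the limit of > 100000 nM in this assay, at which 2 of the 3 values shown sit.

The exchange from 4-chlorobenzyl to 3-cyanobenzyl alters both the group and the ring position that carries it, and the compounds shown do not separate these two changes. As far as these compounds go, whether an amine or a carboxylic acid at the place of the nitrile would keep, lose or extend the step also stays open.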